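Swapping an Aminophenyl for a Hydroxyphenyl Group

The source may hold more compounds than are shown below. What is called first, only, known or untested is meant among the compounds shown, and "the series" means these compounds.

Compound 1 `COc1cc(OC)cc(-c2cc3ccccc3c(-c3cccc(N)c3)n2)c1` in an ADME assay on MCF-10A cells (Homo sapiens) for cytotoxicity, read by CCK-8 assay and cell counting, with a stated time of 72 h (on this read-out lower numbers stand for stronger inhibition and higher numbers for weaker inhibition), gives > 50000 nM, which is a limit of the assay rather than a number (the limit of > 50000 nM in this assay, at which 1 of the 3 values shown sits).
Compound 2 `COc1cc(OC)cc(-c2cc3ccccc3c(-c3ccc(O)cc3)n2)c1` in this assay gives 7280 nM.
Compound 3 `COc1ccc(-c2cc3cc(C)ccc3c(-c3cccc(N)c3)n2)cc1OC` in this assay gives 5600 nM.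

Compound 1 and compound 2 differ in one place: 4-hydroxyphenyl in place of 3-aminophenyl on an aromatic carbon. This change gave an at least 6.8-fold lower number from compound 1 to compound 2 (0.83 log units; beyond the scatter). The still unmeasured compound 4 `COc1ccc(-c2cc3cc(C)ccc3c(-c3ccc(O)cc3)n2)cc1OC` differs from compound 3 by the same change, made at the same place: 4-hydroxyphenyl in place of 3-aminophenyl on an aromatic carbon. How the core of compound 1 differs from the core of compound 3 is not broken down here. Compound 2 and compound 3 sit within the scatter of each other, so neither can be ranked ahead of the other.

The earlier step started from a limit, and its full size is not known. Because the same change gave an at least 6.8-fold lower number from compound 1 to compound 2 (0.83 log units; beyond the scatter), a step of about a 2.2-fold lower number from compound 3 to compound 4 (0.35 log units; beyond the scatter) is expected in this assay, smaller than the earlier one. Compound 4 is therefore estimated at 2500 nM, most likely between 900 nM and 7000 nM.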

Compound 4, half-maximal inhibitory concentration: 18100 nM
Estimate against measurement, compound 4: 7.2-fold (0.86 log units) below; the measured number lies above the stated range.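

On the core of compound 3, placing 4-hydroxyphenyl where 3-aminophenyl stood gave a 3.2-fold higher number from compound 3 to compound 4 (0.51 log units; beyond the scatter) in this assay, the opposite direction to the step seen on the core of compound 1. For the compounds shown here, with only two cores, this shows that neither the size nor the direction of the change carried over here, but it does not show which difference between the cores is responsible, and the two steps clearly disagree: the same change on two cores in this assay, an at least 6.8-fold lower number (0.83 log units; beyond the scatter) from compound 1 to compound 2 and a 3.2-fold higher number (0.51 log units; beyond the scatter) from compound 3 to compound 4, at least 22-fold (1.34 log units) apart, beyond the scatter of two such steps. Going by these compounds, compound 1 gives > 50000 nM, which is a limit of the assay and not a number, so the full size of the earlier step remains unknown.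

The compounds shown leave open which structural difference between the two cores decides the direction of the step, and whether a third core would follow either one. Also open, on these data alone, is how this assay would respond to another group in the same place, such as a carboxylic acid or an amide.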